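The compounds below may be only part of what the source reports. "The series", "measured", "known", "first", "only" and "open" are said of these compounds alone.

Compound 1 `CCCCn1c(S)nnc1COc1ccc(-c2ccccc2)cc1` gives 75% in a functional assay on the whole organism (strain Wistar) for inhibition, with Rattus norvegicus as the target, read by paw edema, with a stated time of 3 h, at a dose of 10 mg/kg by the oral route; on this read-out lower numbers stand for less inhibition and higher numbers for more inhibition at the one dose given (going by the name of the read-out). Compound 2 `Sc1nnc(COc2ccc(-c3ccccc3)cc2)n1-c1ccc(Cl)cc1`, which carries 4-chlorophenyl in place of butyl on an aromatic nitrogen, gives 15.9% in this assay; that change was a number 59.1 percentage points lower from compound 1 to compound 2 (beyond the scatter). For the measured compounds named here, of the two numbers measured so far, compound 2 stands at the lowest, with compound 1 as its only neighbour, a good deal higher. Compound 3 `Sc1nnc(COc2ccc(-c3ccccc3)cc2)n1-c1ccc(Br)cc1` differs from compound 2 by bromo in place of chloro on an aromatic carbon. Going by the values given here, no measured step covers this exchange: the single step known, from compound 1 to compound 2, swaps the whole group on the nitrogen rather than one atom on that group, so it gives little guidance here. Exchanging chloro for bromo is a small change, and in this assay a step of a number 2.1 percentage points higher from compound 2 to compound 3 (within the scatter) is expected, inside the scatter. Compound 3 is therefore estimated at 18%, in a range from 5% to 40%.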

Compound 3, a percentage reported as inhibition, in the whole organism at one dose (the size of the read-out at that dose, not a potency): 31.8%
Compound 3: the middle estimate sits 13.8 percentage points below what was measured, and the stated range covers the measured number.
By their numbers in this assay, from the lowest: compound 2; then compound 3; then compound 1.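

In this assay the atom para to a large group on the phenyl ring matters: the exchange of chloro for bromo, one heavy atom for another with no hydrogen-bond donor or acceptor on either side, gives a number 15.9 percentage points higher from compound 2 to compound 3 (beyond the scatter) and so moves the read-out beyond the scatter. The group on the nitrogen still counts for more, since 4-bromophenyl in place of butyl gives a number 43.2 percentage points lower from compound 1 to compound 3 (beyond the scatter) and that step is large even with the better of the two halogens. Nothing available explains why bromo differs from chloro here.

As far as these compounds go, two halogens make no trend, so it remains open how fluoro, iodo, methoxy or an amine at the same place would read. From the compounds shown here alone, it is also open whether a longer chain such as hexyl on the nitrogen would hold the level seen with butyl.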